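From 2,4-dichlorophenyl to 3,4-dichlorophenyl

This account rests on a few compounds, and the source may have more. Where it says the series, first, only, none or still open, it means among the compounds named here.

- compound 1 `COc1ccc(/C=C2\CCC/C(=C\c3cccc(OC)c3OC)C2=O)cc1`: 16300 nM
- compound 2 `COc1cccc(/C=C2\CCC/C(=C\c3cccc(O)c3)C2=O)c1OC`: 8500 nM
- compound 3 `COc1cccc(/C=C2\CCC/C(=C\c3ccc(Cl)cc3Cl)C2=O)c1OC`: > 20000 nM (a limit, not a number)

All three compounds were tested in a functional assay on HT-1080 cells (Homo sapiens) for cytotoxicity, read by MTT assay, with a stated time of 72 h; on this read-out higher numbers stand for weaker inhibition and lower numbers for stronger inhibition. The entry for compound 3 is a limit: > 20000 nM.

The next compound, compound 4 `COc1cccc(/C=C2\CCC/C(=C\c3ccc(Cl)c(Cl)c3)C2=O)c1OC`, keeps the shared core and has the same atoms as compound 3, joined differently: 3,4-dichlorophenyl in place of 2,4-dichlorophenyl on a double-bonded chain carbon bound to a double-bonded ring carbon.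

Three measured steps change the group at this same place. One shows a 1.9-fold lower number from compound 1 to compound 2 (0.28 log units; within the scatter). Another shows an at least 1.2-fold higher number from compound 1 to compound 3 (0.08 log units; that floor lies within the scatter). The third shows an at least 2.3-fold higher number from compound 2 to compound 3 (0.37 log units; beyond the scatter). None of them swaps one dichlorophenyl group for another, so the data give only a loose guide. Compound 1 gives 16300 nM, and this measured value serves as the anchor for the expectation.

A modest shift toward a lower number is expected, and the expected size is an at least 1.3-fold lower number from compound 3 to compound 4 (0.12 log units; that floor lies within the scatter). A limit could appear again. For compound 4 the estimated value is 15000 nM, with an expected range of 6000 nM to 30000 nM.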

Compound 4, half-maximal inhibitory concentration: 10800 nM
The estimate for compound 4 lay 1.4-fold (0.14 log units) above the measured number; the measured number falls inside the stated range.
By their numbers in this assay, from the lowest: compounds 2, 4 and 1 (each within the scatter of the next). At a limit, above all of these: compound 3.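

In this assay, within the data shown here, putting 3,4-dichlorophenyl in place of 2,4-dichlorophenyl gives an at least 1.8-fold lower number from compound 3 to compound 4 (0.26 log units; that floor lies within the scatter), the first step here in which only the arrangement of the same atoms changes. That step is only a floor, since compound 3 stands at a limit and not at a number: the limit of > 20000 nM in this assay, at which 1 of the 4 values shown sits. The new group also gives a 1.3-fold higher number from compound 2 to compound 4 (0.10 log units; within the scatter) and a 1.5-fold lower number from compound 1 to compound 4 (0.18 log units; within the scatter), so at this place 3,4-dichlorophenyl reads level with both 3-hydroxyphenyl and 4-methoxyphenyl, and a dichlorophenyl group is not enough on its own to send a compound to the limit.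

On these data alone, the true size of the step between the two dichlorophenyl groups stays open. So does how a phenyl group carrying an amine or a carboxylic acid would read at this place.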